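Pyridin-4-yl replacing 4-hydroxyphenyl on the sulfur: series notes

The source may hold more compounds than are shown below. What is called first, only, known or untested is meant among the compounds shown, and "the series" means these compounds.

Measured in a functional assay on the whole organism with Mus musculus as the target; a higher number here means that more compound is needed for the effect, a lower number that less compound is needed:
compound 1 `Cc1c(C)c2c(c(C)c1N)CC(C)(C)O2` gives 7.8 mg/kg
compound 2 `Cc1c(C)c2c(c(C)c1N)CC(C)(CSc1ccc(F)cc1)O2` gives 17.9 mg/kg
compound 3 `Cc1c(C)c2c(c(C)c1N)CC(C)(CSc1ccc(O)cc1)O2` gives > 50 mg/kg (a limit, not a number)

Compound 3 has only a limit in this assay, not a number. Among the measured compounds the position is the limit of > 50 mg/kg in this assay, at which 1 of the 3 values shown sits.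

The next structure is compound 4 `Cc1c(C)c2c(c(C)c1N)CC(C)(CSc1ccncc1)O2`. The change is pyridin-4-yl in place of 4-hydroxyphenyl on a sulfur, with pyridin-4-yl in place of 4-hydroxyphenyl on a sulfur.

Among the measured compounds shown here, one measured step bears on this change, and only indirectly. It is an at least 2.7-fold higher number from compound 2 to compound 3 (0.44 log units; beyond the scatter), beyond the scatter and at least modest, for hydroxy in place of fluoro on an aromatic carbon. Compound 4 also lacks that hydroxy, so a return towards compound 2 at 17.9 mg/kg is expected, though not all the way. For the measured compounds named here, no measured compound here carries a pyridine ring, so this reading is weak, and a result at the limit remains possible.

The expected move in this assay is a modest one to a lower number, estimated as an at least 1.7-fold lower number from compound 3 to compound 4 (0.25 log units; that floor lies within the scatter). For compound 4 the estimated value is 28 mg/kg, with an expected range of 10 mg/kg to 70 mg/kg.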

Compound 4, dose for 50% inhibition: 19.9 mg/kg
Compound 4: middle estimate off by 1.4-fold (0.15 log units), on the high side; the measured number falls inside the stated range.
By their numbers in this assay, from the lowest: compound 1; then compounds 2 and 4 (each within the scatter of the next). At a limit, above all of these: compound 3.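

In this assay, pyridin-4-yl on the sulfur gives an at least 2.5-fold lower number from compound 3 to compound 4 (0.40 log units; beyond the scatter), so the loss seen with 4-hydroxyphenyl does not extend to every replacement of 4-fluorophenyl at this position. Against 4-fluorophenyl the exchange gives a 1.1-fold higher number from compound 2 to compound 4 (0.05 log units; within the scatter), so the two groups cannot be told apart here, although one is an aromatic ring of carbon only and the other an aromatic ring with a hetero atom. Taken against the hydrogen of compound 1, the (pyridin-4-yl)sulfanyl group on the saturated chain carbon gives a 2.6-fold higher number from compound 1 to compound 4 (0.41 log units; beyond the scatter), so this substituent still does not reach the number of the unsubstituted compound.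

The full size of the first step stays open, since compound 3 has only a limit and not a number: the limit of > 50 mg/kg in this assay, at which 1 of the 4 values shown sits.

Also open, as far as these compounds go, is whether an amine or a carboxylic acid on the aromatic ring, or a longer chain carrying that ring on the sulfur, would stay with compound 2 and compound 4, move towards compound 1, or fall to the limit.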